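A few compounds are considered here, and "the series" means these few. Any claim that something is new, unique, unknown or untested is made for them only; others in the source may bear on it.

The three measured compounds share one core and differ only in the aryl group on an aromatic nitrogen. Compound 1 `N#CC1=C(N)Oc2c(c3nc4ccccc4nc3c3ccccc23)C12C(=O)N(Cc1cnnn1-c1ccc(F)cc1)c1ccccc12` carries a 4-fluorophenyl there, compound 2 `N#CC1=C(N)Oc2c(c3nc4ccccc4nc3c3ccccc23)C12C(=O)N(Cc1cnnn1-c1cccc(Cl)c1)c1ccccc12` a 3-chlorophenyl, and compound 3 `COc1ccc(-n2nncc2CN2C(=O)C3(C(C#N)=C(N)Oc4c3c3nc5ccccc5nc3c3ccccc43)c3ccccc32)cc1` a 4-methoxyphenyl. In a functional assay on HepG2 cells (Homo sapiens) for antiproliferative activity, read by MTT assay, with a stated time of 48 h (on this read-out lower numbers stand for stronger inhibition and higher numbers for weaker inhibition), compound 1 gives only a limit of the assay, > 50000 nM. In this assay compound 2 likewise gives only a limit, > 50000 nM. In this assay compound 3 also gives only a limit, > 50000 nM. Compound 3 therefore stands where every value sits: the limit of > 50000 nM in this assay, at which 3 of the 3 values shown sit. The steps a step that the two limits leave unreadable from compound 1 to compound 2, a step that the two limits leave unreadable from compound 1 to compound 3 and a step that the two limits leave unreadable from compound 2 to compound 3 can accordingly not be sized.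

Compound 4 `CC(=O)Nc1ccc(-n2nncc2CN2C(=O)C3(C(C#N)=C(N)Oc4c3c3nc5ccccc5nc3c3ccccc43)c3ccccc32)cc1` keeps the core of compound 3 and differs from it by the change (acetamido in place of methoxy on an aromatic carbon), the 4-methoxyphenyl thereby becoming a 4-acetamidophenyl. Among the measured compounds shown here, none of the measured steps has a readable size, so the three limits show only that variation of this aryl group has so far produced no measurable inhibition. Compound 4 is therefore expected to sit at the limit again. The step that the limit leaves unreadable from compound 3 to compound 4 is estimated as no movement that this assay could reveal. For compound 4 the expected value in this assay is 60000 nM, within a range from 20000 nM to 200000 nM.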

Compound 4, half-maximal inhibitory concentration: > 50000 nM
Compound 4: no number, only a limit; the forecaster's own chance of this, stated with the estimate: 80%; the middle value does not contradict the limit.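

In this assay compound 4 gives only a limit, > 50000 nM. Its steps to compound 1, compound 2 and compound 3 therefore cannot be read, and all four compounds sit together: the limit of > 50000 nM in this assay, at which 4 of the 4 values shown sit. The compounds shown leave open whether any aryl group at this place gives measurable inhibition, and how far these four compounds truly differ.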